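This account rests on a few compounds, and the source may have more. Where it says the series, first, only, none or still open, it means among the compounds named here.

The series is followed in an ADME assay on Vero cells (Chlorocebus sabaeus) for cytotoxicity, read by sulforhodamine B assay, with a stated time of 3 days; a higher number here means that more compound is tolerated, a lower number that less compound is tolerated. Compound 1 `CC1=C(C(=O)Nc2ccc(Cl)cc2)C(c2cccc(Cl)c2)C(C(=O)Nc2ccc(Cl)cc2)=C(C)N1` gives 12 ug/mL. Compound 2 `CC1=C(C(=O)Nc2ccc(Cl)cc2)C(c2ccc(N(C)C)cc2)C(C(=O)Nc2ccc(Cl)cc2)=C(C)N1` differs from it in one place, (4-(dimethylamino)phenyl in place of 3-chlorophenyl on a saturated ring carbon), and in this assay compound 2 gives 155 ug/mL, a step of a 13-fold higher number from compound 1 to compound 2 (1.11 log units; beyond the scatter). Compound 3 `COc1ccc(NC(=O)C2=C(C)NC(=O)NC2c2cccc(Cl)c2)cc1` rests on another core; how its core differs from that of compound 1 is not broken down here. In this assay compound 3 gives 254 ug/mL, and its gap to compound 2 lies within the scatter, so the two cannot be ordered against each other.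

Compound 4 `COc1ccc(NC(=O)C2=C(C)NC(=O)NC2c2ccc(N(C)C)cc2)cc1` has not yet been measured. It stands to compound 3 as compound 2 stands to compound 1: 4-(dimethylamino)phenyl in place of 3-chlorophenyl on a saturated ring carbon. The surroundings of the place are not the same. In compound 1 the saturated ring carbon lies in a six-membered non-aromatic ring with 1 nitrogen, next to two ring atoms that each bear a (4-chlorophenyl)carbamoyl group and two ring bonds from two ring atoms that each bear a methyl group; in compound 3 it lies in a six-membered non-aromatic ring with 2 nitrogen, next to the ring nitrogen and next to the ring atom that bears a large group, two ring bonds from the ring atom that bears a methyl group. The change is therefore the same kind of change, not the same.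

A step as large as a 13-fold higher number from compound 1 to compound 2 (1.11 log units; beyond the scatter) is not expected again, because compound 3 already gives 254 ug/mL and the core around the place differs. The step expected from compound 3 to compound 4 is a 1.8-fold higher number from compound 3 to compound 4 (0.25 log units; within the scatter). Compound 4 is estimated at 450 ug/mL, with an expected range from 160 ug/mL to 1200 ug/mL, and there is a fair chance that this assay reports only a limit for it.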

Compound 4, half-maximal cytotoxic concentration: 236 ug/mL
Beside the measured number, compound 4's estimate is 1.9-fold (0.28 log units) above it, within the range that was stated.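

Carried to the other core, the exchange of 3-chlorophenyl for 4-(dimethylamino)phenyl on the saturated ring carbon gives a 1.1-fold lower number from compound 3 to compound 4 (0.03 log units; within the scatter) and so does not separate the two compounds in this assay. The change therefore does not carry over in size from one core to the other: the same change on two cores in this assay, a 13-fold higher number (1.11 log units; beyond the scatter) from compound 1 to compound 2 and a 1.1-fold lower number (0.03 log units; within the scatter) from compound 3 to compound 4, 14-fold (1.14 log units) apart, beyond the scatter of two such steps. Among the compounds shown here, this shows that, within these four compounds, the large step seen on the core of compound 1 cannot be assumed on another core, but with only one pair on each core it does not show which difference between the cores accounts for the gap, nor how the change would behave on any third core.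

The compounds shown leave open whether a carboxylic acid or a morpholine in place of the dimethylamino group would move the number on either core. They also leave open whether a large step would appear on the core of compound 3 if its amide carried a 4-chlorophenyl group instead of the methoxy-substituted ring, which would help to tell the ring from the amide group as the part that matters.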